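Swapping the Ring Substituent of Compound 3

The compounds below may be only part of what the source reports. "The series", "measured", "known", "first", "only" and "open" are said of these compounds alone.

In a functional assay on LFCl2A cells (Rattus norvegicus) for cytotoxicity (on this read-out higher numbers stand for weaker inhibition and lower numbers for stronger inhibition), three compounds have been measured so far. Compound 1 `O=C1C=C[C@@H](CC2=CCCCC2)O[C@@H]1CO` gives 3000 nM, compound 2 `CC(=O)OC[C@H]1O[C@H](C2CCCC=C2C)C=CC1=O` gives 700 nM, and compound 3 `CCCC(=O)OC[C@H]1O[C@H](CC2=CCCCC2)C=CC1=O` gives 90 nM, the lowest of the three numbers. Compound 4 `CCCC(=O)OC[C@H]1O[C@H](C2CCCC=C2C)C=CC1=O` has not yet been measured. It differs from compound 3 in one place: 2-methylcyclohex-2-en-1-yl in place of (cyclohex-1-en-1-yl)methyl on a saturated ring carbon. Here 2-methylcyclohex-2-en-1-yl stands in place of (cyclohex-1-en-1-yl)methyl on a saturated ring carbon, next to the ring oxygen, and the two structures hold the same atoms joined differently. Among the compounds with values here, the only measured step, a 33-fold lower number from compound 1 to compound 3 (1.52 log units; beyond the scatter), is large, but it concerns the propylcarbonyl group on oxygen, which the new structure keeps, so it does not speak directly to this swap. The closest guide is compound 2, which carries the same 2-methylcyclohex-2-en-1-yl with a different group on that oxygen and gives 700 nM. Within the data shown here, no measured pair isolates the swap, so the estimate remains uncertain. The expected change is modest and toward a higher number, a 2.2-fold higher number from compound 3 to compound 4 (0.35 log units; beyond the scatter). For compound 4 the estimated value in this assay is 200 nM, with an expected range of 60 nM to 650 nM.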

Compound 4, half-maximal inhibitory concentration: 350 nM
Beside the measured number, compound 4's estimate is 1.8-fold (0.24 log units) below it; low and high end bracket the measured number.
By their numbers in this assay, from the lowest: compound 3; then compounds 4 and 2 (each within the scatter of the next); then compound 1.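

The swap of (cyclohex-1-en-1-yl)methyl for 2-methylcyclohex-2-en-1-yl is now isolated in this assay, and it gives a 3.9-fold higher number from compound 3 to compound 4 (0.59 log units; beyond the scatter), even though the two groups have the same heavy atoms and the same ring and double-bond counts. So at this saturated ring carbon, next to the ring oxygen, how those atoms are joined is enough to shift the read-out beyond the scatter. With 2-methylcyclohex-2-en-1-yl in place, the ethyl added on the saturated chain carbon bound to the carbonyl carbon gives a 2.0-fold lower number from compound 2 to compound 4 (0.30 log units; within the scatter), so that change to the ester chain does not separate these two compounds, and no evidence is available to explain either result.

The compounds shown leave open how a benzyl group or a plain cyclohexyl group at this ring carbon would compare with compound 3 at 90 nM in this assay. On these data alone, it also remains open whether a longer chain on the ester, such as pentyl in place of propyl, would move the number with either ring substituent.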